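Shifting a Chlorine onto the Pyrimidinone-Bound Phenyl Ring

A few compounds are considered here, and "the series" means these few. Any claim that something is new, unique, unknown or untested is made for them only; others in the source may bear on it.

Of the compounds shown here, three sharing one core have been measured. Compound 1 `COc1ccc(-c2nc(C)c(C(=O)CSc3nc(-c4ccc(OC)cc4)c(C#N)c(=O)[nH]3)s2)cc1` gives 11.5% in a functional assay on U-87MG ATCC cells for antiproliferative activity against U-87 MG (Homo sapiens), read by MTT assay, with a stated time of 48 h, tested at 100 uM; a higher number here means a weaker effect of the compound at the concentration tested, a lower number a stronger effect. Compound 2 `COc1ccc(-c2nc(SCC(=O)c3sc(-c4ccc(Cl)cc4)nc3C)[nH]c(=O)c2C#N)cc1` gives 16.6%, and compound 3 `COc1cccc(-c2nc(SCC(=O)c3sc(-c4ccc(Cl)cc4)nc3C)[nH]c(=O)c2C#N)c1` gives 8.54%. On these numbers compound 1 stands second highest of three: compound 3 is its nearest neighbour and compound 2 its furthest, yet both gaps lie within the scatter, so no order among the three can be read from them.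

Compound 4 `COc1ccc(-c2nc(C)c(C(=O)CSc3nc(-c4cccc(Cl)c4)c(C#N)c(=O)[nH]3)s2)cc1` is not yet measured. It differs from compound 1 in one place: 3-chlorophenyl in place of 4-methoxyphenyl on an aromatic carbon.

Going by the values given here, two measured steps bear on this change. Exchanging chloro for methoxy on an aromatic carbon gave a number 5.1 percentage points higher from compound 1 to compound 2 (within the scatter), and moving a methoxyphenyl from the 4- to the 3-arrangement gave a number 8.1 percentage points lower from compound 2 to compound 3 (within the scatter). Compound 4 combines both kinds of alteration on the phenyl attached to the core. Since neither step moved the read-out beyond the scatter, no step beyond the scatter is expected here either, in whichever direction.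

Compound 4 is therefore estimated at 12%, with a likely range from 3% to 22%, which corresponds to an expected a number 0.5 percentage points higher from compound 1 to compound 4 (within the scatter).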

Compound 4, a percentage reported as activity, at one concentration (the size of the read-out at that concentration, not a potency): 40.6%
Compound 4: the middle estimate sits 28.6 percentage points below what was measured; measured number outside the range, above it.
By their numbers in this assay, from the lowest: compounds 3, 1 and 2 (each within the scatter of the next); then compound 4.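

In this assay, going by these compounds alone, the replacement of 4-methoxyphenyl by 3-chlorophenyl on the aromatic carbon next to the ring nitrogen gives a number 29.1 percentage points higher from compound 1 to compound 4 (beyond the scatter), the first step to exceed the scatter and one toward a weaker effect at the concentration tested. The earlier step at this same position, a number 8.1 percentage points lower from compound 2 to compound 3 (within the scatter), had stayed within the scatter, so only compound 4 shows that the read-out can respond to what this position carries, at least when 3-chlorophenyl enters in place of 4-methoxyphenyl. No measured evidence is available that explains this shift.

The single step changes two things at once, removing the methoxy group and introducing chlorine at another place on the phenyl, so the compounds shown do not separate the part played by each. On these data alone, it also remains open how the core of compound 1 would behave with 3-methoxyphenyl, with a plain phenyl, or with a phenyl bearing an amine or a carboxylic acid at this position.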